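The source may report more compounds than this note shows. Statements on the series, on what has been measured and on what is new or still open speak of the compounds shown alone.

Measured so far in an assay for displacement of a labelled ligand from Apoptosis regulator Bcl-2 (Homo sapiens), read by fluorescence polarization, with a stated time of 30 min; a lower number here means a stronger inhibitor, a higher number a weaker inhibitor:
compound 1 `CC(C)Oc1ccc(-c2cc(C(=O)O)nn2-c2ccccc2)cc1` gives 7000 nM
compound 2 `O=C(O)c1cc(-c2ccc(OCc3ccccc3)cc2)n(-c2ccccc2)n1` gives > 10000 nM
compound 3 `CC(C)Oc1ccc(C(=O)Nc2c(C(=O)O)nn(-c3ccc(Oc4ccccc4)cc3)c2-c2ccc(OC(C)C)cc2)cc1` gives 140 nM

The value of compound 2 in this assay is a limit of the assay, not a number (the limit of > 10000 nM in this assay, at which 1 of the 3 values shown sits). Compound 1 and compound 2 differ in one place, (benzyl in place of isopropyl on an oxygen on an aromatic ring), and the step is an at least 1.4-fold higher number from compound 1 to compound 2 (0.15 log units; that floor lies within the scatter). Compound 3 has a different core; the difference between the two cores is not broken down here. Compound 4 `CC(C)Oc1ccc(C(=O)Nc2c(C(=O)O)nn(-c3ccc(Oc4ccccc4)cc3)c2-c2ccc(OCc3ccccc3)cc2)cc1` is not yet measured; it differs from compound 3 by benzyl in place of isopropyl on an oxygen on an aromatic ring, the same change at the same place as that between compound 1 and compound 2. From compound 3 to compound 4 the step is expected to be a 2.9-fold higher number from compound 3 to compound 4 (0.46 log units; beyond the scatter), a move to a higher number judged from an at least 1.4-fold higher number from compound 1 to compound 2 (0.15 log units; that floor lies within the scatter) in this assay. Compound 4 is estimated at 400 nM, between 150 nM and 1500 nM.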

Compound 4, inhibition constant: > 10000 nM
Compound 4 was reported as a limit (the forecaster's own chance of this, stated with the estimate: 5%); at least 25-fold (1.39 log units) between middle value and limit.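

Benzyl in place of isopropyl on an oxygen on an aromatic ring, read in this assay, gives an at least 71-fold higher number from compound 3 to compound 4 (1.85 log units; beyond the scatter), so on the core of compound 3 the change is clearly unfavourable. The value of compound 4, > 10000 nM, is a limit of the assay and not a number. This shows that the change moves the same way on the core of compound 3 as far as the data can be read, but it does not show that the size of the step carries from one core to the other: the same change on two cores in this assay, an at least 1.4-fold higher number (0.15 log units; that floor lies within the scatter) from compound 1 to compound 2 and an at least 71-fold higher number (1.85 log units; beyond the scatter) from compound 3 to compound 4; the limit leaves it open whether they differ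

With only isopropyl and benzyl shown on that oxygen, it remains open how a methyl, an ethyl or a longer chain such as butyl would read on either core. Also open, on these data alone, is whether an amine at the end of such a chain would bring the number back down.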